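The source may report more compounds than this note shows. Statements on the series, on what has been measured and on what is new or still open speak of the compounds shown alone.

Measured compounds in this series:
compound 1, `O=c1cc(CSC(=S)N2CCCC2)oc2cc(Cl)ccc12`, > 40000 nM
compound 2, `CC(C)N(C(=S)SCc1cc(=O)c2ccc(Cl)cc2o1)C(C)C`, > 30000 nM
compound 3, `Cc1ccc2c(=O)c(CSC(=S)N3CCCC3)coc2c1`, 4400 nM

The values come from a functional assay on HeLa cells (Homo sapiens) for antiproliferative activity, read by MTT assay, with a stated time of 72 h; on this read-out higher numbers stand for weaker inhibition and lower numbers for stronger inhibition. Compound 1 reaches only a limit of the assay, > 40000 nM. Compound 2 likewise reaches only a limit, > 30000 nM. For the measured compounds named here, compound 3 is the one compound with a number, 4400 nM. The change from compound 1 to compound 2 is diisopropylamino in place of pyrrolidin-1-yl on a thiocarbonyl carbon, and its step is a step that the two limits leave unreadable from compound 1 to compound 2, which cannot be read because the limit of > 40000 nM in this assay, at which 1 of the 3 values shown sits, and the limit of > 30000 nM in this assay, at which 1 of the 3 values shown sits, are the two results. Compound 3 and compound 1 differ in their cores, a difference not broken down here. Compound 4, `Cc1ccc2c(=O)c(CSC(=S)N(C(C)C)C(C)C)coc2c1`, carries the same change as compound 2, namely (diisopropylamino in place of pyrrolidin-1-yl on a thiocarbonyl carbon), applied to compound 3. Since the earlier step is unreadable, the expected step for compound 4 is a 1.4-fold higher number from compound 3 to compound 4 (0.13 log units; within the scatter), assumed close to no change and resting on the value of compound 3, 4400 nM. Compound 4 is estimated at 6000 nM, between 2000 nM and 30000 nM.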

Compound 4, half-maximal inhibitory concentration: 1400 nM
For compound 4 the middle estimate is 4.3-fold (0.63 log units) above the measured one, outside the stated range (below it).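

In this assay, diisopropylamino in place of pyrrolidin-1-yl on a thiocarbonyl carbon gives a 3.1-fold lower number from compound 3 to compound 4 (0.50 log units; beyond the scatter), a modest gain on the core of compound 3. The same change on the core of compound 1 cannot be read, as the results for compound 1 and compound 2 are both limits of the assay and not numbers. The series therefore shows the change on one core only and does not show whether its direction or size carries from one core to the other, and nothing given here accounts for the step.

As far as these compounds go, it remains open whether the gain continues with diethylamino or falls away with morpholin-4-yl on the core of compound 3. From the compounds shown here alone, it also remains open whether either amine would give a readable number on the core of compound 1.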